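The source may hold more compounds than are shown below. What is called first, only, known or untested is meant among the compounds shown, and "the series" means these compounds.

Working notes on the series. Compound 1 `Fc1ccc(/N=C/c2cccs2)cc1Cl`, compound 2 `Fc1ccc(/N=C/c2ccccc2Cl)cc1Cl` and compound 3 `Fc1ccc(/N=C/c2ccccc2Cl)cc1` have been run in a functional assay on CCRF-CEM cells (Homo sapiens), read by cell counting, with a stated time of 72 h; on this read-out lower numbers stand for stronger inhibition and higher numbers for weaker inhibition. Compound 1 gives 25 ug/mL in this assay, compound 2 gives 10 ug/mL, and compound 3 gives 2.1 ug/mL. Compound 3 therefore stands lowest of the three numbers in this assay; its nearest neighbour is compound 2, and compound 1 is furthest off. Among the compounds with values here, the one single-point step among the measured compounds is a 4.8-fold lower number from compound 2 to compound 3 (0.68 log units; beyond the scatter), which strips a chloro from the ring that carries the fluoro.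

Compound 4 `Clc1ccccc1/C=N/c1ccc(Br)cc1` is the next member and has not been measured in this assay. It differs from compound 3 by bromo in place of fluoro on an aromatic carbon, so the halogen on the ring that carries the imine nitrogen is exchanged rather than removed. Within the data shown here, no measured step swaps one halogen for another at that position; the step from compound 2 to compound 3 concerns a different substituent on the same ring and only shows that changes there can move the number by a modest amount. A swap of fluoro for bromo is expected to give a step close to or within the scatter, with no firm direction. The estimated value for compound 4 in this assay is 2.5 ug/mL, with a range from 0.8 ug/mL to 8 ug/mL, which corresponds to an expected step of a 1.2-fold higher number from compound 3 to compound 4 (0.08 log units; within the scatter).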

Compound 4, half-maximal inhibitory concentration: 4.5 ug/mL
Beside the measured number, compound 4's estimate is 1.8-fold (0.26 log units) below it; the measured number falls inside the stated range.
By their numbers in this assay, from the lowest: compound 3; then compound 4; then compound 2; then compound 1.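

In this assay the exchange of fluoro for bromo on an aromatic carbon, para to a group of 9 heavy atoms, gives a 2.1-fold higher number from compound 3 to compound 4 (0.33 log units; beyond the scatter) and so shows that the number at this position depends on which halogen is present. Neither group brings a ring, a hydrogen-bond donor or acceptor, or a net charge, and the step still lies beyond the scatter. The earlier step, a 4.8-fold lower number from compound 2 to compound 3 (0.68 log units; beyond the scatter) on removal of a chloro from the same ring, did not touch this position, and no available measurement bears on what lies behind the new step.

With only fluoro and bromo read at this position, the compounds shown leave open whether the number changes in an orderly way across the halogens and how a hydrogen, an amine or a carboxylic acid would read there. They also leave open whether the same exchange gives a step of like size and direction on the core of compound 2, which carries the additional chloro.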